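From an anilide to a difluorobenzylamide: an expected loss

The source may hold more compounds than are shown below. What is called first, only, known or untested is meant among the compounds shown, and "the series" means these compounds.

In a functional assay on A549 cells (Homo sapiens) for inhibition, read by MTT assay, with a stated time of 48 h (a higher number here means a weaker inhibitor, a lower number a stronger inhibitor), the measured compounds stand as follows:
Compound 1, `COc1ccc2c(=O)c(/C=C/C(=O)Nc3cccc(Cl)c3)coc2c1`: 470 nM
Compound 2, `COc1ccc2c(=O)c(/C=C/C(=O)NCc3ccc(F)cc3)coc2c1`: a limit of the assay, > 100000 nM
Compound 3, `COc1ccc2c(=O)c(/C=C/C(=O)Nc3ccccc3Cl)coc2c1`: 29900 nM

Compound 1 gives the lowest of the two numbers, and the nearest is compound 3, since a 64-fold higher number from compound 1 to compound 3 (1.80 log units; beyond the scatter). The value of compound 2 is a limit and not a number (the limit of > 100000 nM in this assay, at which 1 of the 3 values shown sits). Compound 4, `COc1ccc2c(=O)c(/C=C/C(=O)NCc3ccc(F)cc3F)coc2c1`, is not yet measured. It differs from compound 1 in one place: 2,4-difluorobenzyl in place of 3-chlorophenyl on an amide-type nitrogen. Within the data shown here, two measured steps bear on this change. The closest is the step in which 4-fluorobenzyl replaced the same 3-chlorophenyl on the amide-type nitrogen, where an at least 210-fold higher number from compound 1 to compound 2 (2.32 log units; beyond the scatter). The second is the step from 3-chlorophenyl to 2-chlorophenyl, where a 64-fold higher number from compound 1 to compound 3 (1.80 log units; beyond the scatter). Compound 2 and compound 4 share the benzyl attachment to the amide-type nitrogen; compound 4 carries 2,4-difluorobenzyl where compound 2 carries 4-fluorobenzyl. A large rise in this assay is therefore expected, and most likely the assay will again report only a limit. Compound 4 is expected to give 100000 nM, with a range from 20000 nM to 300000 nM. The expected step is a 210-fold higher number from compound 1 to compound 4 (2.33 log units; beyond the scatter).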

Compound 4, half-maximal inhibitory concentration: 13300 nM
For compound 4 the middle estimate is 7.5-fold (0.88 log units) above the measured one; measured number below the stated range.
By their numbers in this assay, from the lowest: compound 1; then compound 4; then compound 3. At a limit, above all of these: compound 2.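

With 2,4-difluorobenzyl on the amide-type nitrogen, this assay still gives a numerical result, and the replacement of 3-chlorophenyl remains costly, with a 28-fold higher number from compound 1 to compound 4 (1.45 log units; beyond the scatter), while the comparison with the 2-chlorophenyl amide shows a 2.2-fold lower number from compound 3 to compound 4 (0.35 log units; beyond the scatter). The benzyl attachment therefore does not by itself settle the outcome at this position, since fluoro in place of hydrogen on an aromatic carbon of the benzyl group gives an at least 7.5-fold lower number from compound 2 to compound 4 (0.87 log units; beyond the scatter), although compound 1 remains the lowest of the series. Compound 2 still stands at a limit of the assay and not at a number: the limit of > 100000 nM in this assay, at which 1 of the 4 values shown sits.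

The compounds shown do not tell how an unsubstituted benzyl group on the amide-type nitrogen would compare with 4-fluorobenzyl and 2,4-difluorobenzyl, so the separate contribution of each fluoro remains unresolved. They also leave open whether a longer chain, such as 2-phenylethyl, would keep a numerical result in this assay or return to a limit, and whether any such amide could approach compound 1.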